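Swapping the Imidazole of Compound 2 for an Aminopyridazine

The source may hold more compounds than are shown below. What is called first, only, known or untested is meant among the compounds shown, and "the series" means these compounds.

Of the compounds shown here, three sharing one core have been measured in a physicochemical assay for solubility, at pH 7.4; on this read-out lower numbers stand for lower solubility and higher numbers for higher solubility. Compound 1 `Cc1ccc(-c2c[nH]cn2)cc1NC(=O)c1ccc(OCc2ccccn2)cc1` gives 90000 nM, compound 2 `Cc1cc(C)c(-c2ncc[nH]2)cc1NC(=O)c1ccc(OCc2ccccn2)cc1` gives 2000 nM, and compound 3 `Cc1cc(C)c(-c2cccc(N)n2)cc1NC(=O)c1ccc(OCc2ccccn2)cc1` gives 2000 nM. Compound 2 thus stands level with compound 3, the two together at the lowest of the three numbers, while compound 1 lies well above them.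

The unmeasured compound 4 `Cc1cc(C)c(-c2ccc(N)nn2)cc1NC(=O)c1ccc(OCc2ccccn2)cc1` differs from compound 2 in one place: 6-aminopyridazin-3-yl in place of 1H-imidazol-2-yl on an aromatic carbon. Going by the values given here, the only measured step that bears on this exchange is the one in which a 6-aminopyridin-2-yl took the place of the same 1H-imidazol-2-yl, with the result no change at the digits printed from compound 2 to compound 3 (within the scatter). The 6-aminopyridazin-3-yl entering compound 4 resembles that 6-aminopyridin-2-yl in being a six-membered aromatic ring with 2 hetero atoms and in carrying 1 hydrogen-bond donor, though it brings 3 hydrogen-bond acceptors. With a single comparable step, and that one flat, only a small shift is expected in this assay, if anything a modest rise. The expected step is therefore a 1.5-fold higher number from compound 2 to compound 4 (0.18 log units; within the scatter). Compound 4 is estimated at 3000 nM, with a likely range from 1000 nM to 10000 nM.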

Compound 4, solubility: 6000 nM
Compound 4: the middle estimate sits 2.0-fold (0.30 log units) below what was measured, within the range that was stated.
By their numbers in this assay, from the lowest: compounds 2 and 3 (each within the scatter of the next); then compound 4; then compound 1.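

In this assay, this position on the carbon-only ring, ortho to a methyl group and para to a methyl group, now proves sensitive to the group placed there: the earlier exchange gave no change at the digits printed from compound 2 to compound 3 (within the scatter), whereas 6-aminopyridazin-3-yl gives a 3.0-fold higher number from compound 2 to compound 4 (0.48 log units; beyond the scatter). The comparison between the two six-membered groups is more telling, since each is a six-membered aromatic ring with 2 hetero atoms and 1 hydrogen-bond donor, yet the change gives a 3.0-fold higher number from compound 3 to compound 4 (0.48 log units; beyond the scatter), so groups that match on those counts are not interchangeable here. Nothing available accounts for this difference.

The compounds shown leave open whether the higher number in this assay goes with the six-membered ring of 6-aminopyridazin-3-yl or with the amino group it carries, and a methyl or a hydroxyl group in place of that amino group would help separate the two. They also leave open whether the same exchange would give a similar step on a core lacking the two methyl groups.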